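Cytotoxicity notes: fluorophenyl in place of methylpyridinyl

This account rests on a few compounds, and the source may have more. Where it says the series, first, only, none or still open, it means among the compounds named here.

Compound 1 (`Cc1ccc(-c2ccc3[nH]c(=O)nc(-c4ccccc4)c3c2)cn1`) is one of three analogues of a shared core examined in an ADME assay on L6 cells (Rattus norvegicus) for cytotoxicity, read by fluorescence and resazurin assay, with a stated time of 72 h; on this read-out lower numbers stand for an effect already at smaller amounts and higher numbers for an effect only at larger amounts of compound. In this assay compound 1 gives only a limit, > 50000 nM. Compound 2 (`O=c1nc(-c2ccccc2)c2cc(-c3ccc(N4CCCC4)nc3)ccc2[nH]1`) likewise gives only a limit in this assay, > 50000 nM. Compound 3 (`O=c1nc(-c2ccccc2)c2cc(-c3cnc4ccccc4c3)ccc2[nH]1`) gives a limit as well, > 16000 nM. Within the data shown here, two of the three values therefore sit at the limit described by the limit of > 50000 nM in this assay, at which 2 of the 3 values shown sit, the third at the limit described by the limit of > 16000 nM in this assay, at which 1 of the 3 values shown sits; no compound in the set has a read number in this assay, so compound 1 cannot be placed above or below any other.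

Among the measured compounds shown here, the one measured step, a step that the two limits leave unreadable from compound 1 to compound 2, is unreadable from its two limits and gives no size. The change now considered is 4-fluorophenyl in place of 6-methylpyridin-3-yl on an aromatic carbon, leading to compound 4 (`O=c1nc(-c2ccccc2)c2cc(-c3ccc(F)cc3)ccc2[nH]1`). For the measured compounds named here, no measured step addresses this exchange, and the only step in hand cannot be read, so nothing points to an effect beyond the scatter in either direction. The expectation for compound 4 in this assay is that it too is estimated to fall at or beyond the limit, 80000 nM, within 30000 nM to 300000 nM. The step from compound 1 to compound 4 is thus estimated as a step that the limit leaves unreadable from compound 1 to compound 4.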

Compound 4, half-maximal effective concentration: 50000 nM
Beside the measured number, compound 4's estimate is 1.6-fold (0.20 log units) above it; the measured number falls inside the stated range.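

In this assay, among these compounds, compound 4 gives 50000 nM, the only number in the set that is not a limit, so this position on the shared core now carries a read value, here with 4-fluorophenyl, a six-membered aromatic ring of carbon only. The exchange of 6-methylpyridin-3-yl for 4-fluorophenyl removes the ring nitrogen and its hydrogen-bond acceptor, and the outcome is a number no higher from compound 1 to compound 4 (the limit leaves the size open). The size of that step cannot be read because the value for compound 1 is itself a limit, shared with compound 2: the limit of > 50000 nM in this assay, at which 2 of the 4 values shown sit.

Among the compounds shown here, with no pair of read numbers in the set, the effect of any change at this position on the aromatic carbon remains undefined, including how far compound 4 really lies from compound 1. Also open, from the compounds shown here alone, are how a carboxylic acid, a primary amine or a longer alkyl chain at this place would behave in this assay, and how plain phenyl would compare with 4-fluorophenyl.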